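Swapping Phenyl for Ethyl in a Small Series

The source may report more compounds than this note shows. Statements on the series, on what has been measured and on what is new or still open speak of the compounds shown alone.

In an ADME assay on Vero 76 cells (Chlorocebus sabaeus) for cytotoxicity, read by crystal violet staining, with a stated time of 96 h (on this read-out lower numbers stand for higher toxicity in this test and higher numbers for lower toxicity in this test), three compounds have been measured so far: compound 1 (`FC(F)(F)c1cccc(NC(=S)Nc2ccc(I)cc2)c1`) gives 9500 nM, compound 2 (`FC(F)(F)c1cccc(NC(=S)Nc2ccc(Cl)cc2)c1`) gives 11000 nM, and compound 3 (`FC(F)(F)c1cccc(NC(=S)Nc2ccccc2)c1`) gives 39000 nM. Compound 3 stands highest of the three. Chloro in place of iodo gave a 1.2-fold higher number from compound 1 to compound 2 (0.06 log units; within the scatter), while hydrogen in place of iodo gave a 4.1-fold higher number from compound 1 to compound 3 (0.61 log units; beyond the scatter).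

Compound 4 (`CCNC(=S)Nc1cccc(C(F)(F)F)c1`) has not yet been measured. It differs from compound 3 in one place, with ethyl in place of phenyl on an amide-type nitrogen. Among the measured compounds shown here, no measured step makes this change, since all three concern a group on an aromatic carbon, so they bear on it only indirectly. Going by compound 3, where hydrogen in place of chloro gave a 3.5-fold higher number from compound 2 to compound 3 (0.55 log units; beyond the scatter), a modest upward step in this assay is expected, though this is a weak guide and the uncertainty is wide. The expected change is a 2.2-fold higher number from compound 3 to compound 4 (0.34 log units; beyond the scatter). For compound 4 the estimated value is 85000 nM, with an expected range from 35000 nM to 190000 nM.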

Compound 4, half-maximal cytotoxic concentration: > 100000 nM
Compound 4: a limit, no number; the forecaster's own chance of this, stated with the estimate: 40%; at least 1.1-fold (0.07 log units) between middle value and limit.
By their numbers in this assay, from the lowest: compounds 1 and 2 (each within the scatter of the next); then compound 3. At a limit, above all of these: compound 4.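

In this assay compound 4 stands at a limit and not at a number: the limit of > 100000 nM in this assay, at which 1 of the 4 values shown sits.

The earlier steps shown here all concerned a group on an aromatic carbon, whereas this one changes the group on the amide-type nitrogen whose other neighbour is the thiocarbonyl carbon, and ethyl in place of phenyl there gives an at least 2.5-fold higher number from compound 3 to compound 4 (0.40 log units; beyond the scatter). Ethyl in place of 4-chlorophenyl gives an at least 9.0-fold higher number from compound 2 to compound 4 (0.95 log units; beyond the scatter), and ethyl in place of 4-iodophenyl gives an at least 10-fold higher number from compound 1 to compound 4 (1.02 log units; beyond the scatter), so among these compounds all three that carry an aromatic ring on this nitrogen give lower numbers than the one that carries ethyl, with none going against this.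

The compounds shown leave open whether the aromatic ring itself matters or whether any larger group on this nitrogen would do the same, which a cyclohexyl ring or a longer chain in place of ethyl would help to separate. They also leave open whether a chain carrying an amine or a carboxylic acid on this nitrogen would give a number in the range of the aromatic compounds or stay at the limit.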